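The compounds below may be only part of what the source reports. "The series", "measured", "known", "first", "only" and "open" are said of these compounds alone.

Measured compounds:
- compound 1 `COc1nc(C2=NOCC(c3cccc(Cl)c3)N2)ccc1-n1cnc(C)c1`: 15 mL/min/kg
- compound 2 `COc1nc(C2=NOCC(c3cc(Cl)cc(Cl)c3)N2)ccc1-n1cnc(C)c1`: 85 mL/min/kg
- compound 3 `COc1nc(C2=NOC(C)(C)C(c3ccccc3)N2)ccc1-n1cnc(C)c1`: 5 mL/min/kg

All numbers come from an ADME assay on cells (Hepatocyte, Homo sapiens) for pharmacokinetics; on this read-out lower numbers stand for slow clearance and higher numbers for fast clearance. Compound 3 gives 5 mL/min/kg, the lowest of the three, with compound 1 nearest to it at 15 mL/min/kg and compound 2 furthest at 85 mL/min/kg. Compound 1 and compound 2 differ in one place, (chloro in place of hydrogen on an aromatic carbon), and that change brought a 5.7-fold higher number from compound 1 to compound 2 (0.75 log units; beyond the scatter). How the core of compound 3 differs from the core of compound 1 is not broken down here.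

Compound 4 `COc1nc(C2=NOC(C)(C)C(c3ccc(Cl)cc3)N2)ccc1-n1cnc(C)c1` is not yet measured in this assay. It differs from compound 3 by chloro in place of hydrogen on an aromatic carbon. Within the data shown here, this is the same kind of change as the one from compound 1 to compound 2, not the same change: in compound 4 the entering chloro sits para to a large group, while in compound 2 it sits meta to a chloro group and meta to a large group, on a ring that already carried one chloro.

The step expected from compound 3 to compound 4 in this assay is a 2.4-fold higher number from compound 3 to compound 4 (0.38 log units; beyond the scatter), set beside a 5.7-fold higher number from compound 1 to compound 2 (0.75 log units; beyond the scatter). This rests on compound 3 giving 5 mL/min/kg and on the earlier step, allowing for the different surroundings of the new chloro. Compound 4 is therefore expected to give 12 mL/min/kg in this assay. The estimate for compound 4 is expected to fall between 6 mL/min/kg and 25 mL/min/kg.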

Compound 4, clearance: 15 mL/min/kg
The estimate for compound 4 lay 1.3-fold (0.10 log units) below the measured number, within the range that was stated.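

In this assay chloro in place of hydrogen on an aromatic carbon gives a 3.0-fold higher number from compound 3 to compound 4 (0.48 log units; beyond the scatter), so the direction of the step on the core of compound 1 recurs on the core of compound 3, and the sizes of the two steps cannot be told apart: the same change on two cores in this assay, a 5.7-fold higher number (0.75 log units; beyond the scatter) from compound 1 to compound 2 and a 3.0-fold higher number (0.48 log units; beyond the scatter) from compound 3 to compound 4, 1.9-fold (0.28 log units) apart, within the scatter of two such steps

Within these two pairs, the change can therefore be carried from one core to the other with the same direction and no size difference beyond the scatter, but two pairs set no rule for the series. The pairs also differ in more than the core: the chloro entering compound 4 sits para to a large group on a ring with no other chloro, whereas the ring of compound 1 already carries a chloro, so agreement between the steps does not show that core, place on the ring and the chloro already present have no separate influence.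

As far as these compounds go, the phenyl to 4-chlorophenyl change on the core of compound 1 would be needed to separate the core from the place and the existing chloro, and that comparison stays open here. Also open, from the compounds shown here alone, is whether fluoro or a nitrile in the same place on the core of compound 3 would shift clearance as chloro does.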